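A few compounds are considered here, and "the series" means these few. Any claim that something is new, unique, unknown or untested is made for them only; others in the source may bear on it.

Working notes on the series.

Compound 1 `OC[C@H]1O[C@@H](n2cnc3c(NCc4ccc(Br)cc4)ncnc32)[C@H](O)[C@@H]1O` is the parent of this set. Going by the values given here, in a functional assay on CCRF-CEM cells (Homo sapiens) for antiproliferative activity, with a stated time of 72 h (on this read-out higher numbers stand for weaker inhibition and lower numbers for stronger inhibition), compound 1 gives 20600 nM, the highest of the three numbers measured so far. Compound 2 `COc1cccc(CNc2ncnc3c2ncn3[C@@H]2O[C@H](CO)[C@@H](O)[C@H]2O)c1` gives 7600 nM and compound 3 `OC[C@H]1O[C@@H](n2cnc3c(NCc4ccc(Cl)c(Cl)c4)ncnc32)[C@H](O)[C@@H]1O` gives 3800 nM. The step of a 2.7-fold lower number from compound 1 to compound 2 (0.43 log units; beyond the scatter) and the step of a 5.4-fold lower number from compound 1 to compound 3 (0.73 log units; beyond the scatter) both lower the number, each by a modest amount, whereas the step of a 2.0-fold lower number from compound 2 to compound 3 (0.30 log units; within the scatter) stays within the scatter.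

Compound 4 `COc1cccc(CNc2ncnc3c2ncn3[C@@H]2O[C@H](CO)[C@@H](O)[C@H]2O)c1O` has not been measured. Relative to compound 1 the change is 2-hydroxy-3-methoxyphenyl in place of 4-bromophenyl on a saturated chain carbon bound to a nitrogen on an aromatic ring. The step that bears most directly on it is a 2.7-fold lower number from compound 1 to compound 2 (0.43 log units; beyond the scatter), since the entering group of compound 4 carries the 3-methoxyphenyl of compound 2 together with an added hydroxyl. Among the compounds with values here, no measured pair in this set isolates the effect of that hydroxyl, so only the methoxy-bearing comparison is available. As far as these compounds go, on that basis a modest lowering of the number is expected, of roughly the size of a 2.7-fold lower number from compound 1 to compound 2 (0.43 log units; beyond the scatter), with wider uncertainty than usual because the hydroxyl is untested here.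

Compound 4 is therefore estimated at 8000 nM in this assay, with a range from 3000 nM to 25000 nM. The expected step is a 2.6-fold lower number from compound 1 to compound 4 (0.41 log units; beyond the scatter).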

Compound 4, half-maximal inhibitory concentration: 300 nM
The estimate for compound 4 lay 27-fold (1.43 log units) above the measured number; measured number outside the range, below it.
By their numbers in this assay, from the lowest: compound 4; then compounds 3 and 2 (each within the scatter of the next); then compound 1.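

Going by these compounds alone, the single added hydroxy on an aromatic carbon gives a 25-fold lower number from compound 2 to compound 4 (1.40 log units; beyond the scatter) in this assay, a large step that exceeds every step among the earlier compounds. The group on the saturated chain carbon bound to a nitrogen on an aromatic ring therefore moves this read-out far more than the 4-bromophenyl, 3-methoxyphenyl and 3,4-dichlorophenyl variations had shown: 2-hydroxy-3-methoxyphenyl gives a 13-fold lower number from compound 3 to compound 4 (1.10 log units; beyond the scatter) and a 69-fold lower number from compound 1 to compound 4 (1.84 log units; beyond the scatter), both large, which leaves compound 4 with the lowest number of the four, beyond the scatter of each of the others. Nothing at hand explains why the hydroxy has so large an effect.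

The compounds shown leave open whether the hydroxy acts alone or only together with the methoxy, a question that a 2-hydroxyphenyl group would separate. They also leave open whether a hydroxy is specifically required, which an amine, a carboxylic acid or a second methoxy in its place on the 3-methoxyphenyl ring would test.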